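Benzoxaborole chalcones: para-substituent step in cytotoxicity series

This account rests on a few compounds, and the source may have more. Where it says the series, first, only, none or still open, it means among the compounds named here.

Measured so far:
compound 1 `O=C(/C=C/c1ccc2c(c1)B(O)OC2)c1ccc(-c2ccccc2)cc1` — 9500 nM
compound 2 `O=C(/C=C/c1ccc2c(c1)B(O)OC2)c1ccc(O)cc1` — 24100 nM

Among the compounds with values here, in a functional assay on HCT-116 cells (Homo sapiens) for cytotoxicity, read by MTT assay, with a stated time of 48 h (on this read-out lower numbers stand for stronger inhibition and higher numbers for weaker inhibition), compound 2 gives 24100 nM, the highest of the two numbers so far; the nearest is compound 1 with 9500 nM. Within the data shown here, the only measured step, a 2.5-fold higher number from compound 1 to compound 2 (0.40 log units; beyond the scatter), is a modest one and concerns a different exchange at the same position.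

Compound 3 `O=C(/C=C/c1ccc2c(c1)B(O)OC2)c1ccc([N+](=O)[O-])cc1` differs from compound 2 by nitro in place of hydroxy on an aromatic carbon. Among the measured compounds shown here, no measured pair here swaps a hydroxy for a nitro, so the step from compound 1 to compound 2 bears on it only as a guide to how much a change at this position has moved this assay at all. On that basis a step of modest size is expected, with no direction settled, and the estimate is placed somewhat below compound 2 toward the middle of the series. For compound 3 the expected value in this assay is 15000 nM, with a range of 5000 nM to 50000 nM, which corresponds to an expected step of a 1.6-fold lower number from compound 2 to compound 3 (0.21 log units; within the scatter).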

Compound 3, half-maximal inhibitory concentration: 9100 nM
Estimate against measurement, compound 3: 1.6-fold (0.22 log units) above; the range from low to high includes it.
By their numbers in this assay, from the lowest: compounds 3 and 1 (each within the scatter of the next); then compound 2.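

In this assay the exchange of hydroxy for nitro gives a 2.6-fold lower number from compound 2 to compound 3 (0.42 log units; beyond the scatter) and so matches in size the earlier exchange at this position, with hydroxy again on the side of the higher number. Nitro and phenyl, though different groups, are not separated here: a 1.0-fold lower number from compound 1 to compound 3 (0.02 log units; within the scatter) is what the exchange between them gives, so among these three groups only hydroxy stands apart. No measurement on hand offers an explanation for this pattern.

Going by these compounds, whether the standing of hydroxy goes with its hydrogen-bond donor remains open, since nitro carries none and three groups at one position are too few to decide it. An amine, a methoxy or a carboxylic acid at this position would bear on that question, and the effect of changes elsewhere on the core remains unaddressed.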